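The compounds below may be only part of what the source reports. "The series", "measured", "known", "first", "only" and "open" are said of these compounds alone.

Measured so far in an ADME assay on MT4 cells (Homo sapiens) for cytotoxicity, read by MTT assay, with a stated time of 5 days; on this read-out higher numbers stand for lower toxicity in this test and lower numbers for higher toxicity in this test:
- Compound 1 `CCC(C)CN(c1ccnc(Nc2ccc(C#N)cc2)n1)c1c(F)cc(-c2ccc(C#N)cc2)cc1F`: > 255000 nM, which is a limit and not a number.
- Compound 2 `N#Cc1ccc(Nc2nccc(N(CC(O)CO)c3c(F)cc(-c4ccc(C#N)cc4)cc3F)n2)cc1`: 19500 nM.

Among the compounds with values here, compound 2 holds the only actual number, so it is the one firm reference point. Compound 3 `COCN(c1ccnc(Nc2ccc(C#N)cc2)n1)c1c(F)cc(-c2ccc(C#N)cc2)cc1F` is unmeasured and differs from it thus: methoxy in place of 1,2-dihydroxyethyl on a saturated chain carbon bound to a nitrogen on an aromatic ring. Within the data shown here, one measured step bears on this change: an at least 13-fold lower number from compound 1 to compound 2 (1.11 log units; beyond the scatter), with 1,2-dihydroxyethyl coming in. Compound 3 gives that group up, so, going by an at least 13-fold lower number from compound 1 to compound 2 (1.11 log units; beyond the scatter), a move back toward higher numbers in this assay is expected. The estimated change is a 3.6-fold higher number from compound 2 to compound 3 (0.56 log units; beyond the scatter). For compound 3 the expected value is 70000 nM, with an estimated range of 20000 nM to 250000 nM.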

Compound 3, half-maximal cytotoxic concentration: 238000 nM
Compound 3: the middle estimate sits 3.4-fold (0.53 log units) below what was measured; measured number inside the range.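

In this assay, putting methoxy in place of 1,2-dihydroxyethyl gives a 12-fold higher number from compound 2 to compound 3 (1.09 log units; beyond the scatter), so the low number of compound 2 does not extend to every oxygen-bearing group at this place. Compound 1 carries only a limit, and the step reads an at least 1.0-fold lower number from compound 1 to compound 3 (0.02 log units; that floor lies within the scatter), so sec-butyl and methoxy cannot be ranked. Any true gap between them stays hidden because of the ceiling of the test: the limit of > 255000 nM in this assay, at which 1 of the 3 values shown sits.

On these data alone, whether a single hydroxyl would bring the number down as well remains open. So does the effect of an amine or a carboxylic acid on this chain carbon.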